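The source may report more compounds than this note shows. Statements on the series, on what has been measured and on what is new or still open speak of the compounds shown alone.

Compound 1 `N=C(N)c1ccc2oc(-c3cccc(OCCCCCOc4ccccc4)c3)cc2c1` is an amidine-bearing molecule with a chain linking two aromatic parts; in an ADME assay on L6 cells (Rattus norvegicus) for cytotoxicity, read by resazurin assay, with a stated time of 70 h (on this read-out higher numbers stand for weaker inhibition and lower numbers for stronger inhibition), compound 1 gives 3000 nM. Compound 2 `N=C(N)c1ccc2oc(-c3cccc(OCCCCCCOc4ccccc4)c3)cc2c1` differs from it only by phenoxymethyl in place of phenoxy on a saturated chain carbon, five bonds along the chain from an oxygen on an aromatic ring, and in this assay compound 2 gives 3100 nM, which amounts to a 1.0-fold higher number from compound 1 to compound 2 (0.01 log units; within the scatter). Compound 3 `N=C(N)c1ccc2cc(-c3cccc(OCCCCCOc4ccccc4)c3)oc2c1` has the same atoms as compound 1 joined differently; the difference between the two cores is not broken down here. In this assay compound 3 gives 4100 nM. Compound 4 `N=C(N)c1ccc2cc(-c3cccc(OCCCCCCOc4ccccc4)c3)oc2c1` has not yet been measured; it differs from compound 3 by phenoxymethyl in place of phenoxy on a saturated chain carbon, five bonds along the chain from an oxygen on an aromatic ring, the same change seen between the first two compounds. Since that earlier change yielded a 1.0-fold higher number from compound 1 to compound 2 (0.01 log units; within the scatter), a step of comparable size is expected for compound 4, namely a 1.0-fold higher number from compound 3 to compound 4 (0.01 log units; within the scatter). For compound 4 the estimated value is 4200 nM, expected to lie between 2000 nM and 8500 nM.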

Compound 4, half-maximal inhibitory concentration: 4300 nM
Compound 4: middle estimate off by 1.0-fold (0.01 log units), on the low side; the range from low to high includes it.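

Putting phenoxymethyl in place of phenoxy on the second core gives a 1.0-fold higher number from compound 3 to compound 4 (0.02 log units; within the scatter) in this assay, so this pair shows no real change. The same swap on the two cores gives steps that cannot be told apart: the same change on two cores in this assay, a 1.0-fold higher number (0.01 log units; within the scatter) from compound 1 to compound 2 and a 1.0-fold higher number (0.02 log units; within the scatter) from compound 3 to compound 4, 1.0-fold (0.01 log units) apart, within the scatter of two such steps. This shows that, on these two cores, the swap leaves the number where it was and that the core made no visible difference to that result, but two pairs do not make a rule for other cores.

Still open, from the compounds shown here alone, is whether this holds for a longer chain such as 3-phenoxypropyl, or for an amine or a carboxylic acid in place of phenoxy. Also open, going by these compounds, is whether a third core would behave like these two.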